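The compounds below may be only part of what the source reports. "The series", "measured", "known", "first", "only" and "open" are said of these compounds alone.

Compound 2 `O=S(=O)(NCCCNCc1ccc(Br)cc1)c1cc(C(F)(F)F)cc(C(F)(F)F)c1` gives 2200 nM in a functional assay on PANC-1 cells (Homo sapiens) for inhibition, read by MTT assay, with a stated time of 72 h (a higher number here means a weaker inhibitor of growth, a lower number a stronger inhibitor of growth), and stands level with compound 1 `O=S(=O)(NCCCCNCc1ccc(Br)cc1)c1cc(C(F)(F)F)cc(C(F)(F)F)c1`, which gives 2200 nM in this assay; the step of no change at the digits printed from compound 1 to compound 2 (within the scatter) lies within the scatter. Compound 3 `COc1ccc(CNCCCNS(=O)(=O)c2cc(C(F)(F)F)cc(C(F)(F)F)c2)cc1` carries methoxy in place of bromo on an aromatic carbon. Within the data shown here, no measured step touches the substituent on that ring; the one step on record alters the chain, so it gives no guide to direction here. A step of a 1.3-fold higher number from compound 2 to compound 3 (0.10 log units; within the scatter) is therefore expected, none beyond the scatter. Compound 3 is estimated at 2800 nM, with a range from 900 nM to 9000 nM.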

Compound 3, concentration for 50% growth inhibition: 11000 nM
The estimate for compound 3 lay 3.9-fold (0.59 log units) below the measured number; the measured number lies above the stated range.
By their numbers in this assay, from the lowest: compounds 1 and 2 (each within the scatter of the next); then compound 3.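

In this assay, the substituent on the aromatic carbon para to a large group moves the number beyond the scatter, which the chain change did not do: methoxy in place of bromo gives a 5.0-fold higher number from compound 2 to compound 3 (0.70 log units; beyond the scatter). With the chain also differing, the step is the same in size, a 5.0-fold higher number from compound 1 to compound 3 (0.70 log units; beyond the scatter), so the shorter chain does not offset the change on the ring. No evidence on hand accounts for this step.

From the compounds shown here alone, whether chloro, fluoro or methyl at that carbon tracks with bromo or with methoxy remains open. So does whether a longer chain would stay level with compound 1 and compound 2.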